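Flat cytotoxicity series: from compound 3 to compound 4

A few compounds are considered here, and "the series" means these few. Any claim that something is new, unique, unknown or untested is made for them only; others in the source may bear on it.

In a functional assay on HepG2 cells (Homo sapiens) for cytotoxicity, read by MTT assay, with a stated time of 72 h (a lower number here means a stronger inhibitor, a higher number a weaker inhibitor), compound 1 `COc1cc2ncnc(Nc3ccc(F)c(Cl)c3)c2cc1NC(=O)N/N=C/c1ccc(F)cc1` gives 31100 nM and compound 2 `COc1ccc(/C=N/NC(=O)Nc2cc3c(Nc4ccc(F)c(Cl)c4)ncnc3cc2OC)cc1` gives 21300 nM while compound 3 `COc1cc2ncnc(Nc3ccc(F)c(Cl)c3)c2cc1NC(=O)N/N=C/c1cc(OC)c(OC)c(OC)c1` gives 30100 nM and so stands within the scatter of both others.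

Compound 4 `COc1cc2ncnc(Nc3ccc(F)c(Cl)c3)c2cc1NC(=O)N/N=C/c1ccc(O)cc1` is not yet measured. Going by the values given here, it carries 4-hydroxyphenyl in place of 3,4,5-trimethoxyphenyl on a carbon with a double bond to nitrogen and no measured compound here carries that group.

Among the compounds with values here, three steps bear on this change: a 1.5-fold lower number from compound 1 to compound 2 (0.16 log units; within the scatter) and a 1.0-fold lower number from compound 1 to compound 3 (0.01 log units; within the scatter) and a 1.4-fold higher number from compound 2 to compound 3 (0.15 log units; within the scatter) all change the same aryl group, and none leaves the scatter. Going by these compounds, no step beyond the scatter is therefore expected in this assay for compound 4, although a free hydroxy group remains untested. The expected step is a 1.1-fold lower number from compound 3 to compound 4 (0.05 log units; within the scatter) and carries no direction that could be relied on. For compound 4 the estimated value is 27000 nM with an expected range from 13000 nM to 55000 nM.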

Compound 4, half-maximal inhibitory concentration: 26300 nM
The estimate for compound 4 lay 1.0-fold (0.01 log units) above the measured number; the range from low to high includes it.
By their numbers in this assay, from the lowest: compounds 2, 4, 3 and 1 (each within the scatter of the next).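

In this assay the free hydroxy group, new to this aryl position, still gives only steps within the scatter: a 1.1-fold lower number from compound 3 to compound 4 (0.06 log units; within the scatter) and a 1.2-fold higher number from compound 2 to compound 4 (0.09 log units; within the scatter) and a 1.2-fold lower number from compound 1 to compound 4 (0.07 log units; within the scatter). Replacing 3,4,5-trimethoxyphenyl with 4-hydroxyphenyl on a carbon with a double bond to nitrogen removes heavy atoms and adds a hydrogen-bond donor, yet the number stays within the scatter, so the flat picture now extends to a hydroxy group as well as fluoro and methoxy groups. No supporting measurement accounts for this flat result.

Going by these compounds, whether an amine, a carboxylic acid or a longer chain on this aryl ring would give a step beyond the scatter remains open. The four compounds also leave open whether any change to the shared core would move the number in this cell assay.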